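Amide ring swaps on the shared core: compound 2 to compound 3

A few compounds are considered here, and "the series" means these few. Any claim that something is new, unique, unknown or untested is made for them only; others in the source may bear on it.

Measured in a functional assay on HCC 2998 cells (Homo sapiens) for inhibition, read by colorimetric assay and sulforhodamine B assay, with a stated time of 48 h; a lower number here means a stronger inhibitor of growth, a higher number a weaker inhibitor of growth:
- compound 1 `CCCCCCCCCCCC[C@@H](O)[C@H]1CC[C@H]([C@H](O)CCCCCCCCCCNC(=O)c2ccco2)O1` gives 100000 nM
- compound 2 `CCCCCCCCCCCC[C@@H](O)[C@H]1CC[C@H]([C@H](O)CCCCCCCCCCNC(=O)c2cncs2)O1` gives 100000 nM

Within the data shown here, compound 2 stands level with compound 1, its only measured comparison in this assay. The next structure is compound 3 `CCCCCCCCCCCC[C@@H](O)[C@H]1CC[C@H]([C@H](O)CCCCCCCCCCNC(=O)c2ccsc2)O1`, which carries thiophen-3-yl in place of 1,3-thiazol-5-yl on a carbonyl carbon. The counted difference reads (thiophen-3-yl in place of 1,3-thiazol-5-yl on a carbonyl carbon). Among the measured compounds shown here, one measured step bears on this change, and it sits at the same place: no change at the digits printed from compound 1 to compound 2 (within the scatter). That step put 1,3-thiazol-5-yl in place of furan-2-yl and gave no size of change to work from. The new swap again exchanges one five-membered aromatic ring for another, so no step beyond the scatter is expected in this assay, and no direction can be assigned. For the measured compounds named here, this rests on a single step, and no compound in the set shows a different value, so the data do not show what would move the number. The estimated change is no change at the digits printed from compound 2 to compound 3 (within the scatter). Compound 3 is expected at 100000 nM, with an estimated range from 40000 nM to 130000 nM.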

Compound 3, concentration for 50% growth inhibition: 2190 nM
For compound 3 the middle estimate is 46-fold (1.66 log units) above the measured one; the whole stated range lies above it.
By their numbers in this assay, from the lowest: compound 3; then compounds 1 and 2 (each within the scatter of the next).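

In this assay, the ring on the carbonyl carbon now proves able to move the number: the change to thiophen-3-yl gives a 46-fold lower number from compound 2 to compound 3 (1.66 log units; beyond the scatter), and the comparison with the furan-2-yl amide gives a 46-fold lower number from compound 1 to compound 3 (1.66 log units; beyond the scatter). The earlier exchange of furan-2-yl for 1,3-thiazol-5-yl gave no separation, so swapping one five-membered aromatic ring for another is not neutral at this place in every case; here, the ring that enters has 1 hetero atom and 1 hydrogen-bond acceptor, and the ring that leaves has 2 of each. Nothing available accounts for the separation of thiophen-3-yl from the other two rings.

The compounds shown leave open whether the lower number follows the thiophene ring as such or its point of attachment, which a thiophen-2-yl, phenyl or pyridin-3-yl group on the same carbonyl carbon would help to separate. Also open, going by these compounds, is whether the step holds on a changed core, such as one with a shorter chain between the amide nitrogen and the shared core.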